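A few compounds are considered here, and "the series" means these few. Any claim that something is new, unique, unknown or untested is made for them only; others in the source may bear on it.

Compound 3 `CC(C)C(=O)NC1CCN(c2ccc3cc(NC(=O)CCc4ccc(C(F)(F)F)cc4)ccc3n2)C1` gives the lowest number of the three measured in a functional assay on HEK293 cells for activation of melanin-concentrating hormone receptor 1 (Rattus norvegicus), read by inositol phosphate accumulation (a lower number here means that less compound is needed, a higher number that more compound is needed for the effect), at 90 nM. Compound 2 `CN(c1ccc2cc(NC(=O)CCc3ccc(C(F)(F)F)cc3)ccc2n1)C1CCCC1` gives 350 nM, and compound 1 `O=C(CCc1ccc(C(F)(F)F)cc1)Nc1ccc2nc(N3CC4CC3CN4)ccc2c1` gives 490 nM; the two steps towards compound 3 are a 3.9-fold lower number from compound 2 to compound 3 (0.59 log units; beyond the scatter) and a 5.4-fold lower number from compound 1 to compound 3 (0.74 log units; beyond the scatter), while a 1.4-fold lower number from compound 1 to compound 2 (0.15 log units; within the scatter) lies within the scatter. Compound 4 `Nc1ccc2cc(NC(=O)CCc3ccc(C(F)(F)F)cc3)ccc2n1` carries amino in place of 3-((isopropylcarbonyl)amino)pyrrolidin-1-yl on an aromatic carbon. Both steps that end at compound 3 bear on this change: each puts the amide-bearing pyrrolidine in place of another substituent at the same place and lowers the number modestly. Removing that group entirely is therefore expected to raise the number, with a step of a 6.7-fold higher number from compound 3 to compound 4 (0.82 log units; beyond the scatter). A level around that of compound 1 and compound 2, or somewhat higher, seems plausible. For compound 4 the estimate is 600 nM, within 200 nM to 2000 nM.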

Compound 4, half-maximal effective concentration: 720 nM
Compound 4: the middle estimate sits 1.2-fold (0.08 log units) below what was measured, within the range that was stated.
By their numbers in this assay, from the lowest: compound 3; then compounds 2, 1 and 4 (each within the scatter of the next, the first and the last beyond it).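

Replacing the group next to the ring nitrogen with amino gives an 8.0-fold higher number from compound 3 to compound 4 (0.90 log units; beyond the scatter) and so undoes all of the advantage of 3-((isopropylcarbonyl)amino)pyrrolidin-1-yl at this place. Amino gives a 2.1-fold higher number from compound 2 to compound 4 (0.31 log units; beyond the scatter) against cyclopentyl(methyl)amino but a 1.5-fold higher number from compound 1 to compound 4 (0.17 log units; within the scatter) against the substituent with two five-membered rings, so only the latter cannot be told apart from amino. Nothing at hand explains these steps.

Still open, going by these compounds, is whether the low number of compound 3 depends on the pyrrolidine ring or on its isopropylcarbonyl amide. Unsubstituted pyrrolidin-1-yl and 3-aminopyrrolidin-1-yl would separate the two parts.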